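Cyclohexyl in place of hexyl on the amide-type nitrogen

A few compounds are considered here, and "the series" means these few. Any claim that something is new, unique, unknown or untested is made for them only; others in the source may bear on it.

The series shares the core of compound 1 `CCCCCCNC(=O)/N=C(\N)NCCCc1sc(N)nc1C` and varies the substituent on the amide-type nitrogen of the urea-like carbonyl. For the measured compounds named here, in an assay on membranes from Sf9 cells for displacement of a labelled ligand from histamine H2 receptor (Homo sapiens), read by scintillation counting, with a stated time of 60 min (on this read-out lower numbers stand for stronger inhibition and higher numbers for weaker inhibition), compound 1 gives 28.8 nM, the lowest of the three numbers measured so far. Compound 2 `Cc1nc(N)sc1CCCN/C(N)=N/C(=O)NCC(C)C1CCCCC1` gives 39.8 nM, and compound 3 `Cc1nc(N)sc1CCCN/C(N)=N/C(=O)NCC(C)CC1CCCCC1` gives 70.8 nM. The step of a 1.4-fold higher number from compound 1 to compound 2 (0.14 log units; within the scatter) is within the scatter, whereas a 2.5-fold higher number from compound 1 to compound 3 (0.39 log units; beyond the scatter) is a modest loss; between the two ring-bearing analogues, a 1.8-fold higher number from compound 2 to compound 3 (0.25 log units; within the scatter) is within the scatter.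

Compound 4 `Cc1nc(N)sc1CCCN/C(N)=N/C(=O)NC1CCCCC1` differs from compound 1 in one place: cyclohexyl in place of hexyl on an amide-type nitrogen. Going by the values given here, no measured step reproduces this exact change. Among the compounds with values here, the steps that bear on it are a 1.4-fold higher number from compound 1 to compound 2 (0.14 log units; within the scatter) and a 2.5-fold higher number from compound 1 to compound 3 (0.39 log units; beyond the scatter), in which a cyclohexyl ring enters on a saturated chain carbon bound to the amide-type nitrogen rather than on the nitrogen itself; one is within the scatter and the other a modest loss. Closing the chain into a ring directly on the nitrogen is therefore expected to give at most a small upward step, or none beyond the scatter, a 1.6-fold higher number from compound 1 to compound 4 (0.19 log units; within the scatter). Compound 4 is estimated at 45 nM, with a range from 18 nM to 110 nM.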

Compound 4, inhibition constant: 170 nM
Compound 4: middle estimate off by 3.8-fold (0.58 log units), on the low side; measured number above the stated range.
By their numbers in this assay, from the lowest: compounds 1, 2 and 3 (each within the scatter of the next, the first and the last beyond it); then compound 4.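

Read in this assay the exchange of hexyl for cyclohexyl on an amide-type nitrogen is a modest loss (a 5.9-fold higher number from compound 1 to compound 4 (0.77 log units; beyond the scatter)) and the largest step so far in this small set, although the leaving and entering groups both hold six carbons. The ring as such does not carry a loss of this size: with a cyclohexyl ring further out on the chain, compound 2 stays within the scatter of compound 1 (a 1.4-fold higher number from compound 1 to compound 2 (0.14 log units; within the scatter)), and compound 3 shows a smaller modest step (a 2.5-fold higher number from compound 1 to compound 3 (0.39 log units; beyond the scatter)), so at this position the result depends on where the ring sits and not only on its presence. No measurement at hand gives a cause for the step to compound 4.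

Still open, going by these compounds, is whether the loss is particular to cyclohexyl on this nitrogen or also holds for a cyclopentyl or phenyl ring there. An unbranched cyclohexylmethyl or cyclohexylethyl group on the same nitrogen would show how much chain is needed to bring the number back to that of compound 1.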